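The compounds below may be only part of what the source reports. "The series", "measured", "known", "first", "only" and "open" are said of these compounds alone.

In an assay (Rattus norvegicus) for inhibition of Fatty-acid amide hydrolase 1 (Homo sapiens) (on this read-out higher numbers stand for weaker inhibition and lower numbers for stronger inhibition), three compounds have been measured: compound 1 `O=C(CCCCCCc1ccccc1)c1ncc(-c2cccc(C(=O)C(F)(F)F)c2)o1` gives 16 nM; compound 2 `N#Cc1cccc(-c2cnc(C(=O)CCCCCCc3ccccc3)o2)c1` gives 15 nM; compound 3 `O=C(CCCCCCc1ccccc1)c1ncc(-c2ccc(C(=O)C(F)(F)F)cc2)o1` gives 65 nM.

From compound 1 to compound 2 the change is cyano in place of (trifluoromethyl)carbonyl on an aromatic carbon, and it made a 1.1-fold lower number from compound 1 to compound 2 (0.03 log units; within the scatter). Compound 4 `N#Cc1ccc(-c2cnc(C(=O)CCCCCCc3ccccc3)o2)cc1` carries the same kind of change relative to compound 3, namely (cyano in place of (trifluoromethyl)carbonyl on an aromatic carbon); the surroundings differ, since in compound 1 the group sits meta to a large group and in compound 3 para to a large group. How the core of compound 1 and the core of compound 3 differ is not broken down here; their values show compound 3 gives the higher number. Because the earlier change gave a 1.1-fold lower number from compound 1 to compound 2 (0.03 log units; within the scatter), a similarly small step is expected here, namely a 1.1-fold lower number from compound 3 to compound 4 (0.03 log units; within the scatter). Compound 4 is therefore estimated at 60 nM, expected to lie between 25 nM and 150 nM.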

Compound 4, inhibition constant: 40 nM
The estimate for compound 4 lay 1.5-fold (0.18 log units) above the measured number; the range from low to high includes it.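

In this assay, putting cyano in place of (trifluoromethyl)carbonyl gave a 1.6-fold lower number from compound 3 to compound 4 (0.21 log units; within the scatter), and the swap carried over between the two cores with no gap beyond the usual scatter: the same change on two cores in this assay, a 1.1-fold lower number (0.03 log units; within the scatter) from compound 1 to compound 2 and a 1.6-fold lower number (0.21 log units; within the scatter) from compound 3 to compound 4, 1.5-fold (0.18 log units) apart, within the scatter of two such steps. Among these compounds, this shows only that the swap behaved alike on these two cores; two pairs cannot show that it would do so on any other core, and they do not explain the result. Placement counted for more in this one pair, where 4-cyanophenyl in place of 3-cyanophenyl gave a 2.7-fold higher number from compound 2 to compound 4 (0.43 log units; beyond the scatter).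

The compounds shown leave open whether a carboxylic acid or an amine in place of cyano would follow the same picture. They also leave open how a shorter chain on the carbonyl would change these numbers.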